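A few compounds are considered here, and "the series" means these few. Any claim that something is new, unique, unknown or untested is made for them only; others in the source may bear on it.

Compound 1 `CCCCCCCCCCc1ccc(-c2noc(CC3CNC3)n2)cc1` stands second highest of the three compounds measured in an assay on HeLa cells for inhibition of sphingosine-1-phosphate transporter SPNS2 (Mus musculus), read by LC-MS, tested at 2 uM (on this read-out higher numbers stand for more inhibition at the one concentration tested (going by the name of the read-out) and lower numbers for less inhibition), where compound 1 gives 63%. Compound 2 `CCCCCCCCCCc1ccc(-c2noc(C3CCNCC3)n2)cc1` gives 66%, the step being a number 3 percentage points higher from compound 1 to compound 2 (within the scatter). Compound 3 `CCCCCCCCCCc1ccc(-c2noc([C@H]3CCC[C@@H](N)C3)n2)cc1` gives 29%, the step being a number 34 percentage points lower from compound 1 to compound 3 (beyond the scatter). Compound 4 `CCCCCCCCCCc1ccc(-c2noc([C@H](N)CCCCN)n2)cc1` differs from compound 1 in one place: 1,5-diaminopentyl in place of (azetidin-3-yl)methyl on an aromatic carbon. The step to piperidin-4-yl and the step of a number 37 percentage points lower from compound 2 to compound 3 (beyond the scatter) bear on this change: one amine-bearing group in place of another can leave the inhibition unchanged or lower it strongly. Within the data shown here, the 1,5-diaminopentyl has no ring, and no measured step tests such a group, so a moderate downward step a number 18 percentage points lower from compound 1 to compound 4 (beyond the scatter) in this assay is expected. Compound 4 is therefore estimated at 45%, within 20% to 70%.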

Compound 4, a percentage reported as inhibition, at one concentration (the size of the read-out at that concentration, not a potency): 50%
The estimate for compound 4 lay 5 percentage points below the measured number; low and high end bracket the measured number.
By their numbers in this assay, from the lowest: compound 3; then compound 4; then compounds 1 and 2 (each within the scatter of the next).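

In this assay, the open-chain 1,5-diaminopentyl shows that a group with no ring can still give clear inhibition at this position, though less than the ringed groups of the two best compounds: a number 13 percentage points lower from compound 1 to compound 4 (beyond the scatter) and a number 16 percentage points lower from compound 2 to compound 4 (beyond the scatter). It also gives more than the ringed 3-aminocyclohexyl, with a number 21 percentage points higher from compound 3 to compound 4 (beyond the scatter), so the presence of a ring alone does not order these groups. Nothing measured here accounts for these steps.

The compounds shown leave open whether the second amine, the chain or the defined stereocentre sets the value of compound 4. A pentyl chain bearing a single amine, or the opposite stereocentre, would separate these.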